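Moving the Chloro Group Along the Benzyl Ring

The source may hold more compounds than are shown below. What is called first, only, known or untested is meant among the compounds shown, and "the series" means these compounds.

Compound 1 `CCC(COc1cccc(C(F)(F)F)c1)OC(=O)NCc1ccccc1`, compound 2 `CCC(COc1cccc(C(F)(F)F)c1)OC(=O)Nc1ccccc1` and compound 3 `CCC(COc1cccc(C(F)(F)F)c1)OC(=O)NCc1ccccc1Cl` share one core and differ only in the group on the carbamate nitrogen. In an assay for inhibition of zeta-carotene desaturase, chloroplastic/chromoplastic (Capsicum annuum), using a Dixon plot, with a stated time of 8 h (a higher number here means a weaker inhibitor, a lower number a stronger inhibitor), compound 1 reaches only the limit of the assay, > 100000 nM. Compound 2 likewise gives only a limit in this assay, > 100000 nM. Compound 3 also stands at a limit in this assay, > 100000 nM. The steps a step that the two limits leave unreadable from compound 1 to compound 2, a step that the two limits leave unreadable from compound 1 to compound 3 and a step that the two limits leave unreadable from compound 2 to compound 3 therefore cannot be read, since the limit of > 100000 nM in this assay, at which 3 of the 3 values shown sit, holds all three values shown. Compound 4 `CCC(COc1cccc(C(F)(F)F)c1)OC(=O)NCc1cccc(Cl)c1` has not yet been measured; it differs from compound 3 by 3-chlorophenyl in place of 2-chlorophenyl on a saturated chain carbon bound to an amide-type nitrogen. Going by the values given here, none of the measured steps carries this same change, and with compound 3 itself at a limit there is no readable precedent. Compound 4 is therefore expected to remain near the limit as well, with the step that the limit leaves unreadable from compound 3 to compound 4 expected to be small. The estimate for compound 4 in this assay is 200000 nM, within 50000 nM to 1000000 nM.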

Compound 4, half-maximal inhibitory concentration: > 100000 nM
Compound 4 ended at the assay's limit; the forecaster's own chance of this, stated with the estimate: 85%; the middle value is on the limit's open side.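

Compound 4 sits at a limit in this assay, as do compound 1, compound 2 and compound 3, so no new step can be read: the limit of > 100000 nM in this assay, at which 4 of the 4 values shown sit.

The compounds shown leave open whether 2-chlorobenzyl and 3-chlorobenzyl differ at all, and whether any group on the carbamate nitrogen gives a readable value in this assay.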